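Swapping the Ring on the Thiocarbonyl Carbon

The source may report more compounds than this note shows. Statements on the series, on what has been measured and on what is new or still open speak of the compounds shown alone.

Of the compounds shown here, two built on a shared core have been measured so far, and a third awaits its number. Compound 1 `N/C(=N\NC(=S)N1CCN(c2ccccn2)CC1)c1ccc(F)cn1` carries a piperidine-like ring that itself bears a pyridinyl group; in a functional assay on A-375 cells (Homo sapiens) for cytotoxicity, read by MTT assay, with a stated time of 72 h (a higher number here means a weaker inhibitor, a lower number a stronger inhibitor), compound 1 gives 1400 nM. Compound 2 `N/C(=N\NC(=S)N1CCCC1)c1ccc(F)cn1` carries the smaller pyrrolidin-1-yl group on the thiocarbonyl carbon, and in this assay compound 2 gives 860 nM. Of the two numbers, that of compound 2 is the lower, but the gap between compound 1 and compound 2 is within the usual scatter of repeated measurements, so the two cannot be told apart with confidence.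

Compound 3 `N/C(=N\NC(=S)N1CCOCC1)c1ccc(F)cn1` differs from compound 2 in one place: morpholin-4-yl in place of pyrrolidin-1-yl on a thiocarbonyl carbon. Among the compounds with values here, no measured pair shows the effect of this exchange. Given that the gap from compound 1 to compound 2 stays within the scatter, a step of similar modest size is expected here, if anything toward a slightly higher number. Compound 3 is therefore expected to give about 1200 nM, within a range from 500 nM to 3000 nM, which would mean an expected step of a 1.4-fold higher number from compound 2 to compound 3 (0.14 log units; within the scatter).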

Compound 3, half-maximal inhibitory concentration: 1500 nM
The estimate for compound 3 lay 1.3-fold (0.10 log units) below the measured number, and the stated range covers the measured number.
By their numbers in this assay, from the lowest: compounds 2, 1 and 3 (each within the scatter of the next).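

Within the data shown here, this is the first exchange at the thiocarbonyl carbon that changes only one place: in this assay, morpholin-4-yl in place of pyrrolidin-1-yl gives a 1.7-fold higher number from compound 2 to compound 3 (0.24 log units; within the scatter). The exchange turns a five-membered ring into a six-membered one and brings in an oxygen atom with one hydrogen-bond acceptor, yet compound 2 and compound 3 cannot be told apart in this cell test, so this particular change has no clear effect on the read-out. No accompanying measurement bears on this result, so it shows only the size of the step and says nothing about what lies behind it.

The compounds shown leave open whether a quite different group on the thiocarbonyl carbon, such as an open-chain dimethylamino group or a ring bearing a carboxylic acid, would move the number beyond the scatter. They also leave open whether the exchange from pyrrolidin-1-yl to morpholin-4-yl would give a similar step on a core carrying chlorine instead of fluorine.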